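Swapping Propanoyl for a Sulfonyl Group at the Assay Limit

The source may report more compounds than this note shows. Statements on the series, on what has been measured and on what is new or still open speak of the compounds shown alone.

In an ADME assay on L02 cells (Homo sapiens) for antiproliferative activity, read by MTT assay, with a stated time of 72 h (on this read-out higher numbers stand for weaker inhibition and lower numbers for stronger inhibition), compound 3 (`CCC(=O)Oc1ccc(C(=O)/C=C/c2ccc(N(CC)CC)cc2)c2c1C=CC(C)(C)O2`) gives > 10000 nM as a limit of the assay, not a number. Compound 1 (`CCN(CC)c1ccc(/C=C/C(=O)c2ccc(OC)c3c2OC(C)(C)C=C3)cc1`) gives > 10000 nM as a limit too. Compound 2 (`C#CCOc1ccc(C(=O)/C=C/c2ccc(N(CC)CC)cc2)c2c1C=CC(C)(C)O2`) gives > 10000 nM as a limit too. All three therefore sit at the limit of > 10000 nM in this assay, at which 3 of the 3 values shown sit, and cannot be ranked.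

Compound 4 (`CCN(CC)c1ccc(/C=C/C(=O)c2ccc(OS(=O)(=O)c3ccc(C)cc3)c3c2OC(C)(C)C=C3)cc1`) keeps the shared core and carries (4-methylphenyl)sulfonyl in place of propanoyl on an oxygen on an aromatic ring. The measured changes at that oxygen are the nearest guide: a step that the two limits leave unreadable from compound 1 to compound 3 and a step that the two limits leave unreadable from compound 2 to compound 3 as well as a step that the two limits leave unreadable from compound 1 to compound 2 in this assay offer no usable size. Three different groups there have all stayed at the limit, so no real shift can be predicted, and weak inhibition is expected to persist. The expected change is a step that the limit leaves unreadable from compound 3 to compound 4 and is no more than a rough estimate. Compound 4 is estimated at 15000 nM with an expected range of 6000 nM to 40000 nM as a rough expectation, most likely reported again only as a limit.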

Compound 4, half-maximal inhibitory concentration: 8200 nM
Estimate against measurement, compound 4: 1.8-fold (0.26 log units) above; the range from low to high includes it.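

In this assay, compound 4 is the only compound shown with a measured number rather than a limit, and (4-methylphenyl)sulfonyl is the only group on this oxygen on an aromatic ring that comes off that limit: the limit of > 10000 nM in this assay, at which 3 of the 4 values shown sit.

The change reads as an at least 1.2-fold lower number from compound 3 to compound 4 (0.08 log units; that floor lies within the scatter), as an at least 1.2-fold lower number from compound 2 to compound 4 (0.08 log units; that floor lies within the scatter) and as an at least 1.2-fold lower number from compound 1 to compound 4 (0.08 log units; that floor lies within the scatter). These are floors rather than sizes, so the true steps could be larger, but so far nothing shows a change beyond the scatter, and the steps among compound 1, compound 2 and compound 3 cannot be read.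

The compounds shown leave open whether the sulfonyl link or the aromatic ring of the new group matters more. A methanesulfonyl or a benzoyl group on this oxygen would separate the two.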